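This account rests on a few compounds, and the source may have more. Where it says the series, first, only, none or still open, it means among the compounds named here.

Measured in a functional assay on the whole organism (strain Kunming) with Mus musculus as the target, in the formalin test, with a stated time of 0.5 h; on this read-out lower numbers stand for an effect already at smaller amounts and higher numbers for an effect only at larger amounts of compound:

- Compound 1 `COc1cc(OC)c(OC)cc1/C=C/COC(=O)/C=C/c1ccc(Br)cc1`: 105 mg/kg
- Compound 2 `COc1cc(OC)c(OC)cc1/C=C/COC(=O)/C=C/c1cc(OC)c(OC)c(OC)c1`: 85.5 mg/kg

Only these two compounds have been measured so far, so there is little to compare. Compound 1 shows 105 mg/kg and compound 2 shows 85.5 mg/kg. These two numbers lie within the usual scatter of repeated measurements, so they cannot be told apart, and compound 1 stands level with compound 2.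

The next compound is compound 3 `COc1cc(OC)c(OC)cc1/C=C/COC(=O)/C=C/c1ccc(Cl)cc1`, which keeps the core of compound 1 and changes one atom: chloro in place of bromo on an aromatic carbon. In words, this is chloro in place of bromo on an aromatic carbon, para to a large group, turning 4-bromophenyl into 4-chlorophenyl.

For the measured compounds named here, no two measured compounds show this exchange, so the data offer no direct guide. The expectation therefore starts from compound 1 at 105 mg/kg, and no step beyond the scatter is expected in this assay. The expected size of the change is a 1.1-fold lower number from compound 1 to compound 3 (0.02 log units; within the scatter). For compound 3 the estimated value is 100 mg/kg, with an expected range from 55 mg/kg to 180 mg/kg.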

Compound 3, dose for half-maximal effect: 108 mg/kg
Compound 3: middle estimate off by 1.1-fold (0.03 log units), on the low side; the measured number falls inside the stated range.
By their numbers in this assay, from the lowest: compounds 2, 1 and 3 (each within the scatter of the next).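

In this assay, for the compounds shown here, putting chloro in place of bromo on this aromatic carbon, para to a large group, gives a 1.0-fold higher number from compound 1 to compound 3 (0.01 log units; within the scatter) and so offers the first direct reading of a change at this position: here, the two groups cannot be told apart. This turns 4-bromophenyl into 4-chlorophenyl and leaves the rest of the molecule untouched, so the comparison isolates one atom, although a single pair on the core of compound 1 sets no general rule. No measurement shown here offers an explanation for this result.

Going by these compounds, what remains open is whether this position tolerates groups of a quite different kind, such as an amine, a carboxylic acid or a longer chain, or whether the level reading is limited to exchanges between bromo and chloro. On these data alone, it is also open whether the same exchange would read the same way on a different aromatic carbon of this six-membered ring, or on a molecule with a different core.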